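Dithiocarbamate benzamides: from an indoline to a pyridylmethylamine

The compounds below may be only part of what the source reports. "The series", "measured", "known", "first", "only" and "open" are said of these compounds alone.

Measured compounds:
compound 1 `Nc1ccccc1NC(=O)c1ccc(CSC(=S)N2CCN(c3ccccc3)CC2)cc1`, 840 nM
compound 2 `Nc1ccccc1NC(=O)c1ccc(CSC(=S)N2CCN(c3ccc(F)cc3)CC2)cc1`, "not determined" (no result reported)
compound 3 `Nc1ccccc1NC(=O)c1ccc(CSC(=S)N2CCc3cc(Cl)ccc32)cc1`, "not determined" (no result reported)

In a functional assay on HeLa cells (Homo sapiens) for antiproliferative activity, read by CCK-8 assay, with a stated time of 72 h (on this read-out lower numbers stand for stronger inhibition and higher numbers for weaker inhibition), compound 1 gives 840 nM. In this assay compound 2 gives "not determined" (no result reported). In this assay compound 3 gives "not determined" (no result reported). Compound 2 and compound 3 were thus run without a single number being reported, so compound 3 stands nowhere on the numbers shown: neither above nor below compound 1. The step to compound 4 `CCN(Cc1ccncc1)C(=S)SCc1ccc(C(=O)Nc2ccccc2N)cc1` is ethyl((pyridin-4-yl)methyl)amino in place of 5-chloro-2,3-dihydro-1H-indol-1-yl on a thiocarbonyl carbon. For the measured compounds named here, no measured pair shows a step of this kind, so no direction can be read from the data; any step in this assay is expected to stay near the range set by compound 1 rather than far beyond the scatter. Compound 4 is therefore expected at about 1200 nM, with a range from 300 nM to 5000 nM.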

Compound 4, half-maximal inhibitory concentration: 1040 nM
Compound 4: middle estimate off by 1.2-fold (0.06 log units), on the high side; low and high end bracket the measured number.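

No step can be read from compound 3 to compound 4, as compound 3 has no single number in this assay. The compounds shown leave open how replacing 5-chloro-2,3-dihydro-1H-indol-1-yl with ethyl((pyridin-4-yl)methyl)amino shifts activity. No supporting evidence bears on this result.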